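The compounds below may be only part of what the source reports. "The series", "measured", "known", "first", "only" and "open" are said of these compounds alone.

Compound 1 `COc1cc(-c2ccnc3cc(-c4ccc(C)c(C)c4)nn23)cc(OC)c1OC` gives 272 nM in a functional assay on A549 cells (Homo sapiens) for inhibition, read by CCK-8 assay, with a stated time of 48 h; a lower number here means a stronger inhibitor, a higher number a weaker inhibitor. Compound 3 `COc1cc(-c2ccnc3cc(-c4ccc(C(C)=O)cc4)nn23)cc(OC)c1OC` gives 4100 nM in this assay. Compound 2 `COc1cc(-c2ccnc3cc(-c4cccc(C#N)c4)nn23)cc(OC)c1OC` reaches only > 10000 nM in this assay, which is a limit of the measurement and not a number.

Among the numbers shown, compound 1 stands lowest; its nearest neighbour is compound 3, with a 15-fold higher number from compound 1 to compound 3 (1.18 log units; beyond the scatter). Compound 4 `COc1ccc(-c2cc3nccc(-c4cc(OC)c(OC)c(OC)c4)n3n2)cc1` has not yet been measured in this assay. It differs from compound 1 in one place: 4-methoxyphenyl in place of 3,4-dimethylphenyl on an aromatic carbon. Within the data shown here, two measured steps bear on this change, since both also replace the 3,4-dimethylphenyl of compound 1 on the same aromatic carbon: an at least 36-fold higher number from compound 1 to compound 2 (1.56 log units; beyond the scatter) and a 15-fold higher number from compound 1 to compound 3 (1.18 log units; beyond the scatter). Both steps went upward and beyond the scatter, and compound 2 sits at the limit of > 10000 nM in this assay, at which 1 of the 3 values shown sits. Only two such replacements are shown, so the size of the step for 4-methoxyphenyl is uncertain, but its direction is expected to be upward. Compound 4 is therefore expected to give about 1300 nM in this assay, within a range from 400 nM to 4500 nM. That estimate corresponds to an expected 4.8-fold higher number from compound 1 to compound 4 (0.68 log units; beyond the scatter).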

Compound 4, half-maximal inhibitory concentration: 376 nM
The estimate for compound 4 lay 3.5-fold (0.54 log units) above the measured number, outside the stated range (below it).
By their numbers in this assay, from the lowest: compounds 1 and 4 (each within the scatter of the next); then compound 3. At a limit, above all of these: compound 2.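

In this assay, the earlier replacements of 3,4-dimethylphenyl on this aromatic carbon had both gone upward, but this one does not separate from it: a 1.4-fold higher number from compound 1 to compound 4 (0.14 log units; within the scatter), so the position tolerates at least one other substituted phenyl group. The substituent on that phenyl ring matters, as methoxy in place of acetyl gives an 11-fold lower number from compound 3 to compound 4 (1.04 log units; beyond the scatter), and 4-methoxyphenyl in place of 3-cyanophenyl gives an at least 26-fold lower number from compound 2 to compound 4 (1.42 log units; beyond the scatter). That second step has only a bound, as compound 2 stands at a limit of the measurement and not at a number: the limit of > 10000 nM in this assay, at which 1 of the 4 values shown sits.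

On these data alone, whether an amine or a carboxylic acid on the phenyl ring would be tolerated remains open. The set also cannot separate the kind of group from where it sits, since 3-cyanophenyl and 4-acetylphenyl differ in both.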